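A Methyl Added to the Ring Nitrogen of Compound 1

The source may report more compounds than this note shows. Statements on the series, on what has been measured and on what is new or still open speak of the compounds shown alone.

Going by the values given here, in a functional assay on the whole organism for antagonist activity, with Mus musculus as the target, in the maximal electroshock model (on this read-out higher numbers stand for an effect only at larger amounts of compound and lower numbers for an effect already at smaller amounts), compound 1 (`COC(=O)NC1=NC(c2ccc(Cl)cc2)CN1`) gives about 200 mg/kg, the highest number of the three compounds measured so far. Compound 2 (`CC(C)OC(=O)NC1=NC(c2ccccc2F)CN1C`) gives 23 mg/kg and compound 3 (`CC(C)OC(=O)NC1=NC(c2ccccc2Cl)CN1C`) gives 35 mg/kg, both clearly lower than compound 1.

The next structure, compound 4 (`COC(=O)NC1=NC(c2ccc(Cl)cc2)CN1C`), keeps the core of compound 1 and changes one place: methyl in place of hydrogen on an amine nitrogen in a ring. In words, this is methyl in place of hydrogen on an amine nitrogen in a ring.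

Among the compounds with values here, the only measured single change is a 1.5-fold higher number from compound 2 to compound 3 (0.18 log units; within the scatter), which lies within the scatter. It swaps chloro for fluoro, so it says nothing directly about this methyl. Compound 2 and compound 3 do carry the same methyl, but they also differ from compound 1 in other groups, and the data cannot separate these differences.

A move to a lower number in this assay is therefore expected, though probably not all the way to the number of compound 3, which gives 35 mg/kg. The expected change is a 2.5-fold lower number from compound 1 to compound 4 (0.40 log units; beyond the scatter) and remains a rough estimate. Compound 4 is estimated at 80 mg/kg, with an expected range from 30 mg/kg to 200 mg/kg in this test.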

Compound 4, dose for half-maximal effect: 66 mg/kg
The estimate for compound 4 lay 1.2-fold (0.08 log units) above the measured number; the measured number falls inside the stated range.
By their numbers in this assay, from the lowest: compounds 2, 3 and 4 (each within the scatter of the next, the first and the last beyond it); then compound 1.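

In this assay, methyl in place of hydrogen on an amine nitrogen in a ring gives a 3.0-fold lower number from compound 1 to compound 4 (0.48 log units; beyond the scatter), and as nothing else in the core of compound 1 changes, this step can be read for that nitrogen alone. Going by these compounds alone, it is the first direct reading of this position, since the earlier single step, chloro in place of fluoro on an aromatic carbon, concerned another part of the structure and could say nothing about the methyl. The hydrogen on this ring nitrogen can thus give way to one carbon with an effect at smaller amounts of compound, not larger ones, although the compounds shown offer no measurement that explains the shift.

A single step at one position cannot show whether a longer chain such as ethyl, or an acetyl group, on the same nitrogen would take the number further down or bring it back up. Nor can it show whether the methyl step holds in the setting of compound 2 and compound 3, which carry this methyl but also differ from compound 1 in other groups.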